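The source may hold more compounds than are shown below. What is called first, only, known or untested is meant among the compounds shown, and "the series" means these compounds.

Three compounds of the series carry numbers in an assay on isolated protein for inhibition of histone deacetylase 8 (Homo sapiens), read by fluorescence, with a stated time of 5 min, tested at 1 uM; a lower number here means a weaker effect, a higher number a stronger effect of the compound at the concentration tested. Compound 1, `CCCNNC(=O)c1cnc(NCc2cccc3ccccc23)nc1`, gives 36%. Compound 2, `CCCCCCNNC(=O)c1ccc(C)c(NCc2ccccc2)c1`, gives 2%. Compound 3, `CCCNNC(=O)c1cnc(NCc2cc(Cl)ccc2Cl)nc1`, gives 33%. On these numbers compound 3 stands second highest of the three. Its nearest neighbour is compound 1, whose number lies slightly higher but within the scatter of repeated measurements, so no order between compound 1 and compound 3 can be read. The furthest is compound 2, whose number lies far below and beyond the scatter. Within the data shown here, no two measured compounds differ in only one place, so no single-point step has yet been measured.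

Compound 4, `CCCNNC(=O)c1cnc(NCc2ccccc2Cl)nc1`, is the next to be measured in this assay. It differs from compound 3 in one place: hydrogen in place of chloro on an aromatic carbon. Among the measured compounds shown here, with no measured single-point step to lean on, the expectation rests on compound 1 and compound 3 giving close values despite different groups attached. A step from compound 3 to compound 4 of about a number 5 percentage points lower from compound 3 to compound 4 (within the scatter) is expected, a small drop at most, within the scatter. Compound 4 is accordingly estimated at 28%, with a range from 12% to 44%.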

Compound 4, a percentage reported as inhibition, at one concentration (the size of the read-out at that concentration, not a potency): 43%
For compound 4 the middle estimate is 15 percentage points below the measured one; the range from low to high includes it.
By their numbers in this assay, from the lowest: compound 2; then compounds 3, 1 and 4 (each within the scatter of the next).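

In this assay, hydrogen in place of chloro on an aromatic carbon, meta to a large group and para to a chloro group, gives a number 10 percentage points higher from compound 3 to compound 4 (within the scatter). Among these compounds, this is the first step that changes one place only, and it shows that the chloro group at this position can give way to hydrogen without a shift beyond the scatter. No measurement at hand gives a reason for this step.

From the compounds shown here alone, whether a methoxy group, an amine or a carboxylic acid at this position would move the read-out beyond the scatter remains open, as does the contribution of the chloro group that stays in compound 4. The low number of compound 2 cannot be tied to any one place, since compound 2 differs from the others in more than one.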